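Dipropylamino for (ethylcarbamoyl)amino: working notes

This account rests on a few compounds, and the source may have more. Where it says the series, first, only, none or still open, it means among the compounds named here.

Compound 1 `CCNC(=O)Nc1nc(-c2ccc(OCC)cc2)c(-c2cc(OC)c(OC)c(OC)c2)s1`: 10.6 nM
Compound 2 `CCOc1ccc(-c2nc(NS(=O)(=O)c3ccc([N+](=O)[O-])cc3OC)sc2-c2cc(OC)c(OC)c(OC)c2)cc1`: > 5000 nM

Among the compounds with values here, in a functional assay on SMMC-7221 cells (Homo sapiens) for antiproliferative activity, read by MTT assay, with a stated time of 48 h (a higher number here means a weaker inhibitor, a lower number a stronger inhibitor), compound 1 gives 10.6 nM, the only actual number so far. Compound 2 reads > 5000 nM, which is a limit of the assay and not a number. Compound 3 `CCCN(CCC)c1nc(-c2ccc(OCC)cc2)c(-c2cc(OC)c(OC)c(OC)c2)s1` has dipropylamino in place of (ethylcarbamoyl)amino on an aromatic carbon of the core of compound 1: dipropylamino in place of (ethylcarbamoyl)amino on an aromatic carbon. Within the data shown here, no measured pair tests this change, so the expectation is tentative. In this assay a weakening well beyond the usual scatter is expected, the estimated step being a 28-fold higher number from compound 1 to compound 3 (1.45 log units; beyond the scatter). Compound 3 is estimated at 300 nM, with an expected range of 40 nM to 2500 nM.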

Compound 3, half-maximal inhibitory concentration: > 5000 nM
Compound 3: no number, only a limit; the forecaster's own chance of this, stated with the estimate: 15%; middle value at least 16-fold (1.22 log units) from the limit.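

In this assay, within the data shown here, dipropylamino in place of (ethylcarbamoyl)amino on this aromatic carbon gives an at least 470-fold higher number from compound 1 to compound 3 (2.67 log units; beyond the scatter), the first step between compounds that differ in one place. The shared core alone therefore does not carry the activity of compound 1. Compound 3 stands only as a limit of the assay and not as a number: the limit of > 5000 nM in this assay, at which 2 of the 3 values shown sit.

This single step changes the hydrogen-bond donors and the chains together, so it cannot tell which of the two counts. An ethylamino group or a primary amine on this carbon would separate them.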